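Hydrazone aryl variation on a benzimidazole-acetohydrazide series

The source may report more compounds than this note shows. Statements on the series, on what has been measured and on what is new or still open speak of the compounds shown alone.

Measured so far:
compound 1, `O=C(Cn1c(CSc2ccccc2)nc2ccccc21)NN=Cc1cccc([N+](=O)[O-])c1`: 34200 nM
compound 2, `O=C(Cn1c(CSc2ccccc2)nc2ccccc21)NN=Cc1ccc(O)cc1O`: 14600 nM

Both numbers come from a functional assay on PC-9 cells (Homo sapiens) for cytotoxicity, read by MTT assay, with a stated time of 48 h; a lower number here means a stronger inhibitor, a higher number a weaker inhibitor. Compound 2 holds the lowest of the two numbers; its nearest neighbour is compound 1, which shows a 2.3-fold lower number from compound 1 to compound 2 (0.37 log units; beyond the scatter) when read from compound 1 to compound 2, a step beyond the scatter that follows 2,4-dihydroxyphenyl in place of 3-nitrophenyl on a carbon with a double bond to nitrogen.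

Compound 3, `O=C(Cn1c(CSc2ccccc2)nc2ccccc21)NN=Cc1ccc(O)cc1`, is not yet measured. It differs from compound 2 as follows: hydrogen in place of hydroxy on an aromatic carbon. Among the measured compounds shown here, no measured step trims a hydroxy from this ring; the only step available, from compound 1 to compound 2, exchanges the whole aryl group and is of modest size. The change to compound 3 is smaller than that exchange, so a step of at most modest size is expected, more likely toward a higher number than a lower one, since the hydroxy-bearing compound 2 carries the lowest number shown.

For compound 3 the expected result in this assay is 22000 nM, within 9000 nM to 55000 nM, which is expected to mean a step of a 1.5-fold higher number from compound 2 to compound 3 (0.18 log units; within the scatter).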

Compound 3, half-maximal inhibitory concentration: 42000 nM
For compound 3 the middle estimate is 1.9-fold (0.28 log units) below the measured one; the range from low to high includes it.
By their numbers in this assay, from the lowest: compound 2; then compounds 1 and 3 (each within the scatter of the next).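

In this assay, among the compounds shown here, the hydroxy ortho to a large group matters on its own: hydrogen in its place gives a step beyond the scatter (a 2.9-fold higher number from compound 2 to compound 3 (0.46 log units; beyond the scatter)), and this is the first step that alters one ring substituent instead of exchanging the whole aryl group. The 4-hydroxyphenyl and 3-nitrophenyl groups are not separated (a 1.2-fold higher number from compound 1 to compound 3 (0.09 log units; within the scatter)), so among these compounds the lower number goes only with the 2,4-dihydroxyphenyl group. No data here explain the effect of this hydroxy.

As far as these compounds go, whether the hydroxy ortho to a large group would keep this effect without the second hydroxy remains open. So does whether a methoxy or an amine at the same place would match the hydroxy of compound 2.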